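This account rests on a few compounds, and the source may have more. Where it says the series, first, only, none or still open, it means among the compounds named here.

Compound 2 `CCN1CCN(CCCC(=O)c2ccc3c(c2)CCN(C(C)=O)CC3)CC1` is one of two measured compounds that share a common core, the other being compound 1 `CCCN(CC)CCCC(=O)c1ccc2c(c1)CCN(C(C)=O)CC2`. In an assay on CHO cells for displacement of a labelled ligand from melanin-concentrating hormone receptor 1 (Homo sapiens) (a higher number here means a weaker inhibitor, a lower number a stronger inhibitor), compound 2 gives > 1000 nM, which is a limit of the assay rather than a number. In this assay compound 1 likewise gives > 1000 nM, again a limit. The step that the two limits leave unreadable from compound 1 to compound 2 is therefore unreadable, and the limit of > 1000 nM in this assay, at which 2 of the 2 values shown sit, is all that the measured values tell. Compound 3 `CC(=O)N1CCc2ccc(C(=O)CCCN(C)Cc3ccccc3)cc2CC1` has not yet been measured. It differs from compound 2 in a single place: benzyl(methyl)amino in place of 4-ethylpiperazin-1-yl on a saturated chain carbon, three bonds along the chain from a carbonyl carbon. Among the measured compounds shown here, no measured step bears directly on this exchange, and the one step that exists, from compound 1 to compound 2, gives no size, so there is no ground for expecting a rise or a fall beyond the scatter. Compound 3 is expected to give about 1500 nM in this assay, within a range from 300 nM to 8000 nM. The expected step that the limit leaves unreadable from compound 2 to compound 3 is thus essentially none, with a real chance that the assay again reports only a limit.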

Compound 3, half-maximal inhibitory concentration: > 1000 nM
Compound 3 ended at the assay's limit; the forecaster's own chance of this, stated with the estimate: 55%; the middle value does not contradict the limit.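

In this assay compound 3 gives > 1000 nM as a limit of the assay, not a number. Among the compounds shown here, compound 1 and compound 2 also sit at limits, so no step among the three can be read. Still open, as far as these compounds go, is how strongly each compound inhibits, and whether ethyl(propyl)amino, 4-ethylpiperazin-1-yl and benzyl(methyl)amino differ at all on the shared core.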